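A few compounds are considered here, and "the series" means these few. Any claim that something is new, unique, unknown or untested is made for them only; others in the source may bear on it.

Compound 1 `COc1cc(C)cc(-c2c(-c3ccnc(-c4ccc(C(C)=O)cc4)c3)cnn2CC#N)c1` gives 17% in a functional assay on BT-549 cells (Homo sapiens) for cytotoxicity, read by sulforhodamine B assay, with a stated time of 48 h, tested at 1 uM; on this read-out lower numbers stand for a stronger effect and higher numbers for a weaker effect at the one concentration tested.
Compound 2 `COc1cc(C)cc(-c2nn(CC#N)cc2-c2ccc(-c3cccc(C(C)=O)c3)nc2)c1` gives 5% in this assay.
Compound 3 `Cc1cc(O)cc(-c2nn(CC#N)cc2-c2ccnc(-c3ccc(Oc4ccccc4)cc3)c2)c1` gives 4% in this assay.

Of the three numbers in this assay, compound 3 holds the lowest. Its nearest neighbour is compound 2, whose number sits within the scatter of it, so the two cannot be ordered; compound 1 lies furthest away, beyond the scatter, and so shows a weaker effect than compound 3. Compound 4 `Cc1cc(O)cc(-c2nn(CC#N)cc2-c2ccnc(-c3ccc(N(C)C)cc3)c2)c1` has not yet been measured. It differs from compound 3 in one place: dimethylamino in place of phenoxy on an aromatic carbon. Among the compounds with values here, no measured pair follows this same change, so its effect in this assay is unknown; a small step, if any, is expected, more likely toward a higher number than a lower one. Compound 4 is estimated at 12%, with a range from 2% to 35%. The expected step is a number 8 percentage points higher from compound 3 to compound 4 (within the scatter).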

Compound 4, a percentage reported as activity, at one concentration (the size of the read-out at that concentration, not a potency): 4%
For compound 4 the middle estimate is 8 percentage points above the measured one; the range from low to high includes it.
By their numbers in this assay, from the lowest: compounds 3, 4 and 2 (each within the scatter of the next); then compound 1.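

In this assay, dimethylamino in place of phenoxy on an aromatic carbon, para to a large group, gives no change at the digits printed from compound 3 to compound 4 (within the scatter). Within the data shown here, this is the first direct reading of this position, as the earlier compounds offered no pair differing in one place, and it shows that this smaller group without a ring can stand in for phenoxy with no change beyond the scatter at the one concentration tested. Nothing given here explains why the two groups read alike.

On these data alone, it remains open whether a carboxylic acid, a primary amine or a longer alkyl chain at this place would read the same. As far as these compounds go, it also remains open whether compound 3 and compound 4 would separate at lower concentrations.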